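This account rests on a few compounds, and the source may have more. Where it says the series, first, only, none or still open, it means among the compounds named here.

Working notes on the shared core, read in a functional assay on BJAB cells (Homo sapiens) for antiproliferative activity, with a stated time of 4 days; on this read-out lower numbers stand for an effect already at smaller amounts and higher numbers for an effect only at larger amounts of compound. Compound 1 `COc1cc(-c2c(C)nn(-c3nc(-c4ccc(Cl)c(Cl)c4)c(SC(C)C)s3)c2C(=O)O)cc(C(F)(F)F)c1` gives 1380 nM. Compound 2 `Cc1nn(-c2nc(-c3ccc(Cl)c(Cl)c3)c(SC(C)C)s2)c(C(=O)O)c1-c1cccc(C(F)(F)F)c1` gives 22000 nM. Compound 3 `Cc1nn(-c2nc(-c3ccc(Cl)c(Cl)c3)c(SC(C)C)s2)c(C(=O)O)c1-c1cnccn1` gives 14000 nM. Compound 3 stands second highest of the three numbers: the step of a 10-fold higher number from compound 1 to compound 3 (1.01 log units; beyond the scatter) is large, whereas a 1.6-fold lower number from compound 2 to compound 3 (0.20 log units; within the scatter) lies within the scatter. Compound 4 `Cc1nn(-c2nc(-c3ccc(Cl)c(Cl)c3)c(SC(C)C)s2)c(C(=O)O)c1-c1ccncc1` carries pyridin-4-yl in place of pyrazin-2-yl on an aromatic carbon. Among the measured compounds shown here, no measured step makes exactly this exchange. The nearest comparison is a 1.6-fold lower number from compound 2 to compound 3 (0.20 log units; within the scatter), an exchange of one six-membered aryl for another on that aromatic carbon, which left the number within the scatter, while a 16-fold higher number from compound 1 to compound 2 (1.20 log units; beyond the scatter) and a 10-fold higher number from compound 1 to compound 3 (1.01 log units; beyond the scatter) show that the methoxy-bearing aryl of compound 1 is what sets it apart. The step of no change at the digits printed from compound 3 to compound 4 (within the scatter) is therefore expected to be small, with no clear direction. Compound 4 is estimated at 14000 nM, within a range of 5000 nM to 40000 nM.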

Compound 4, half-maximal effective concentration: 5900 nM
Compound 4: the middle estimate sits 2.4-fold (0.38 log units) above what was measured; the range from low to high includes it.
By their numbers in this assay, from the lowest: compound 1; then compound 4; then compounds 3 and 2 (each within the scatter of the next).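

Aryl exchange at this position is not always silent, as the pair compound 2 and compound 3 alone suggested: with a 2.4-fold lower number from compound 3 to compound 4 (0.38 log units; beyond the scatter) one six-membered heteroaromatic ring replacing another is enough to move the number beyond the scatter. Pyridin-4-yl also separates from both substituted phenyl groups, with a 3.7-fold lower number from compound 2 to compound 4 (0.57 log units; beyond the scatter) on one side and a 4.3-fold higher number from compound 1 to compound 4 (0.63 log units; beyond the scatter) on the other, so it falls between them. Still open, going by these compounds, is whether an amine or a fluorine on the pyridin-4-yl ring would shift the number further, and whether a methoxy group on that ring would do what it does on the phenyl ring of compound 1. No measurement on hand accounts for any of these steps.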